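Series notes: from compound 3 to compound 4

A few compounds are considered here, and "the series" means these few. Any claim that something is new, unique, unknown or untested is made for them only; others in the source may bear on it.

The series is read in a functional assay on NCI-H460 cells (Homo sapiens) for cytotoxicity, read by sulforhodamine B assay; a lower number here means a stronger inhibitor of growth, a higher number a weaker inhibitor of growth. Compound 1 `CC1=CC[C@@H]([C@@](C)(O)CCCC(C)(C)NC(=S)NN)CC1` gives 84000 nM. Compound 2 `CC1=CC[C@@H]([C@@](C)(O)CCCC(C)(C)NC(=S)N/N=C\c2ccccc2)CC1` gives > 100000 nM, which is a limit and not a number. Compound 3 `CC1=CC[C@@H]([C@@](C)(O)CCCC(C)(C)NC(=S)N/N=C\c2ccccc2[N+](=O)[O-])CC1` gives > 100000 nM, which is also a limit and not a number. Compound 3 therefore has no measured value and stands at the limit of > 100000 nM in this assay, at which 2 of the 3 values shown sit.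

Compound 4 `CC1=CC[C@@H]([C@@](C)(O)CCCC(C)(C)NC(=S)N/N=C\c2cccc(Cl)c2)CC1` carries one structural change: 3-chlorophenyl in place of 2-nitrophenyl on a carbon with a double bond to nitrogen. In words, 3-chlorophenyl stands in place of 2-nitrophenyl on a carbon with a double bond to nitrogen.

Going by the values given here, two measured steps bear on this change. The first is an at least 1.1-fold higher number from compound 1 to compound 2 (0.07 log units; that floor lies within the scatter), and it brings in the aromatic ring. The second is a step that the two limits leave unreadable from compound 2 to compound 3, and it places nitro on that ring. Among the compounds with values here, neither gives a readable size for a change of ring substituent, and no measured compound carries chlorine. With no step beyond the scatter shown, none is expected in this assay in either direction, and compound 4 is expected to stay near the limit reached with compound 3.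

The expected size is a number no higher from compound 3 to compound 4 (the limit leaves the size open). For compound 4 the estimated value is 100000 nM, with an expected range from 50000 nM to 200000 nM.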

Compound 4, concentration for total growth inhibition: > 100000 nM
Compound 4: no number, only a limit; the forecaster's own chance of this, stated with the estimate: 65%; the middle value lies on the limit itself.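

In this assay compound 4 gives > 100000 nM, which is a limit of the assay and not a number. Going by these compounds alone, the steps to compound 4 from compound 2 and from compound 3 cannot be read, and the only readable step is an at least 1.1-fold higher number from compound 1 to compound 4 (0.07 log units; that floor lies within the scatter). A chlorine-bearing ring on the carbon with a double bond to nitrogen therefore gives no number at this position, any more than the unsubstituted phenyl ring or 2-nitrophenyl did, and the series stays where it was: the limit of > 100000 nM in this assay, at which 3 of the 4 values shown sit.

Going by these compounds, the limits give no size for any ring substituent, so how far the ring-bearing compounds lie from compound 1 remains open. On these data alone, what an amine or a carboxylic acid on the ring, or a longer chain in place of the ring, would give in this assay also remains open.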